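A few compounds are considered here, and "the series" means these few. Any claim that something is new, unique, unknown or untested is made for them only; others in the source may bear on it.

Compound 3, `COc1cc(-c2nnc(SCC(=O)Nc3ccccc3)n2N)cc(OC)c1OC`, gives 37900 nM in a functional assay on PC-3 cells (Homo sapiens) for antiproliferative activity, read by MTT assay, with a stated time of 48 h (a lower number here means a stronger inhibitor, a higher number a weaker inhibitor), the lower of the two plain numbers measured, with compound 2 nearest to it. Compound 2, `COc1ccc(C(=O)CSc2nnc(-c3cc(OC)c(OC)c(OC)c3)n2N)cc1`, gives 97900 nM in this assay. Compound 1, `COc1cc(-c2nnc(SCC(=O)c3ccccc3)n2N)cc(OC)c1OC`, reaches only a limit of this assay, > 100000 nM. Changing the group on the carbonyl carbon brought a 2.6-fold lower number from compound 2 to compound 3 (0.41 log units; beyond the scatter) and an at least 2.6-fold lower number from compound 1 to compound 3 (0.42 log units; beyond the scatter). Compound 4, `COc1cc(-c2nnc(SCC(=O)Nc3ccccc3C)n2N)cc(OC)c1OC`, differs from compound 3 by methyl in place of hydrogen on an aromatic carbon. Within the data shown here, none of the measured steps alters this ring; both concern the carbonyl side of the chain, so the expected change is a 1.2-fold lower number from compound 3 to compound 4 (0.07 log units; within the scatter), which lies within the scatter. Compound 4 is therefore estimated at 32000 nM in this assay, with a range from 11000 nM to 95000 nM.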

Compound 4, half-maximal inhibitory concentration: > 100000 nM
Compound 4 ended at the assay's limit (the forecaster's own chance of this, stated with the estimate: 15%); middle value at least 3.1-fold (0.49 log units) from the limit.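

In this assay, the aromatic ring of the anilino group is the first place shown to respond to a small change: methyl ortho to a large group gives an at least 2.6-fold higher number from compound 3 to compound 4 (0.42 log units; beyond the scatter), which removes the advantage compound 3 held. Set against the 4-methoxyphenyl group, the (2-methylphenyl)amino group gives an at least 1.0-fold higher number from compound 2 to compound 4 (0.00 log units; that floor lies within the scatter), a floor within the scatter. The step between compound 1 and compound 4 cannot be read, because both sit at the assay's limit: the limit of > 100000 nM in this assay, at which 2 of the 4 values shown sit.

From the compounds shown here alone, whether a fluoro, chloro or methoxy group at this same place would keep the activity of compound 3 remains open.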